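A Halogen Swap on the Aryl Nitrogen Substituent

The source may hold more compounds than are shown below. What is called first, only, known or untested is meant among the compounds shown, and "the series" means these compounds.

Of the compounds shown here, two have been measured so far. Compound 1 `Fc1cc(Nc2cc(Nc3cccc(Cl)c3)ncn2)ccc1Oc1ccncc1-c1cccnc1` gives 90 nM in a functional assay on MDA-MB-231 cells (Homo sapiens) for cytotoxicity, read by MTT assay, with a stated time of 72 h; a lower number here means a stronger inhibitor, a higher number a weaker inhibitor. Compound 2 `Cn1c(=O)c(C(=O)Nc2ccc(Oc3ccncc3-c3cccnc3)c(F)c2)nn(-c2ccccc2F)c1=O` gives 6760 nM in this assay, the higher of the two numbers; its nearest companion is compound 1, and the gap between the two lies well beyond the scatter. The two compounds differ in much of the molecule, so no single structural change can be read off from this pair.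

Compound 3 `Cn1c(=O)c(C(=O)Nc2ccc(Oc3ccncc3-c3cccnc3)c(F)c2)nn(-c2ccc(Cl)cc2)c1=O` has not yet been measured. It differs from compound 2 in one place: 4-chlorophenyl in place of 2-fluorophenyl on an aromatic nitrogen. For the measured compounds named here, no measured pair shows this exchange, so its effect cannot be taken from these data. For this assay the expectation is a step of modest size from compound 2 to compound 3, more likely toward a lower number than a higher one, and quite possibly not beyond the scatter, estimated as a 1.9-fold lower number from compound 2 to compound 3 (0.29 log units; within the scatter). On that basis compound 3 is expected to give 3500 nM, with a range from 900 nM to 14000 nM.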

Compound 3, half-maximal inhibitory concentration: 3220 nM
Compound 3: the middle estimate sits 1.1-fold (0.04 log units) above what was measured; the range from low to high includes it.
By their numbers in this assay, from the lowest: compound 1; then compound 3; then compound 2.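

For the compounds shown here, on the aromatic nitrogen, 4-chlorophenyl in place of 2-fluorophenyl gives a 2.1-fold lower number from compound 2 to compound 3 (0.32 log units; beyond the scatter) in this assay, which is the first reading of any change at this position. The step is modest but lies beyond the scatter, so this position does respond to the aryl group it carries, even when the exchange keeps the heavy-atom count and leaves the count of hydrogen-bond donors and acceptors at zero. No measurement bears on why the number moves, so the step stands as an observation without an explanation.

The exchange alters the kind of halogen and its place on the phenyl ring together, and the compounds shown cannot separate these two parts or say which of them carries the step. Also open, on these data alone, is how far this position reaches beyond halogenated phenyl groups: an unsubstituted phenyl, a benzyl group, a short alkyl chain, or a phenyl bearing an amine or a carboxylic acid could each move the number by much more or much less than this single step.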